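Swapping the Propyl for a Pyrazole on the Amide Nitrogen

This account rests on a few compounds, and the source may have more. Where it says the series, first, only, none or still open, it means among the compounds named here.

Measured so far:
- In an assay on HEK293 cells for agonist activity at transient receptor potential cation channel subfamily M member 8 (Homo sapiens), read by fluorescence and calcium flux, with a stated time of 15 min (a lower number here means that less compound is needed, a higher number that more compound is needed for the effect), compound 1 `Cc1ccc(OCC(=O)N(Cc2cccs2)c2nccs2)cc1` gives 2240 nM.
- Compound 2 `CCCN(Cc1cccs1)C(=O)COc1ccc(C)cc1` gives 40 nM in this assay.

Among the measured compounds shown here, compound 2 has the lowest of the two numbers; the only other compound, compound 1, stands well above it, as the single measured step of a 56-fold lower number from compound 1 to compound 2 (1.75 log units; beyond the scatter) shows.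

Compound 3 `Cc1ccc(OCC(=O)N(Cc2cccs2)c2cn[nH]c2)cc1` differs from compound 2 by 1H-pyrazol-4-yl in place of propyl on an amide-type nitrogen. The step that bears on this is a 56-fold lower number from compound 1 to compound 2 (1.75 log units; beyond the scatter), in which a five-membered aromatic ring with hetero atoms on the amide-type nitrogen gave way to propyl and the number fell by a large amount. Compound 3 runs the other way, putting a different five-membered aromatic ring with 2 hetero atoms onto the same nitrogen, so a large upward step in this assay is expected, with the exact size uncertain since 1H-pyrazol-4-yl is not 1,3-thiazol-2-yl. Compound 3 is estimated at 1500 nM, between 300 nM and 6000 nM, an expected step of a 38-fold higher number from compound 2 to compound 3 (1.57 log units; beyond the scatter).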

Compound 3, half-maximal effective concentration: 1.4 nM
For compound 3 the middle estimate is 1100-fold (3.03 log units) above the measured one; the measured number lies below the stated range.
By their numbers in this assay, from the lowest: compound 3; then compound 2; then compound 1.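

Compounds 1 and 2 alone could suggest that a five-membered aromatic ring with hetero atoms on the amide-type nitrogen raises the number in this assay, but compound 3 shows this does not hold for every such ring: putting 1H-pyrazol-4-yl in place of propyl gives a 29-fold lower number from compound 2 to compound 3 (1.46 log units; beyond the scatter) rather than a rise. Exchanging one ring for the other gives a 1600-fold lower number from compound 1 to compound 3 (3.20 log units; beyond the scatter) and so shows that, among these compounds, which ring sits on this nitrogen counts for far more than whether a ring is present. The data shown offer no measurement that explains this difference between the two rings.

Still open, from the compounds shown here alone, is whether the hydrogen on the pyrazole nitrogen matters, which a 1-methyl-1H-pyrazol-4-yl group on the same nitrogen would test. Also open, going by these compounds, is how other rings, such as 1H-imidazol-4-yl or pyridin-4-yl, would behave there.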